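From compound 2 to compound 4: isopropylsulfamoyl swap

The source may report more compounds than this note shows. Statements on the series, on what has been measured and on what is new or still open speak of the compounds shown alone.

Three measured entries share the core: compound 1 (`CCCS(=O)(=O)c1cccc(C#Cc2cc(Cl)ccc2OCC(=O)O)c1`), compound 2 (`COCCN(C)S(=O)(=O)c1ccc(C)c(C#Cc2cc(Cl)ccc2OCC(=O)O)c1`) and compound 3 (`CC(C)S(=O)(=O)c1ccc(Cl)c(C#Cc2cc(Cl)ccc2OCC(=O)O)c1`). In an ADME assay on a cell-free system (plasma, Rattus norvegicus) (a higher number here means a larger unbound share of the compound, a lower number a smaller unbound share), compound 1 gives 0.01 and compound 2 gives 0.007, two values within the scatter of each other. For compound 3 the entry reads "not determined" (no result reported). Among the compounds with values here, compound 2 therefore stands within the scatter of the only other number available.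

Compound 4 (`Cc1ccc(S(=O)(=O)NC(C)C)cc1C#Cc1cc(Cl)ccc1OCC(=O)O`) carries isopropylamino in place of (2-methoxyethyl)(methyl)amino on a sulfonyl sulfur. Within the data shown here, no two measured compounds differ in one place, so the series offers no direct guide to this change. The expectation rests only on compound 2 at 0.007 and compound 1 at 0.01. In this assay no step beyond the scatter is expected, and no direction is favoured with any confidence. The estimated step of a 1.4-fold higher number from compound 2 to compound 4 (0.15 log units; within the scatter) stays within the scatter. For compound 4 the expected value is 0.01, with an estimated range from 0.005 to 0.02.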

Compound 4, unbound fraction: 0.004
Compound 4: middle estimate off by 2.5-fold (0.40 log units), on the high side; the whole stated range lies above it.
By their numbers in this assay, from the lowest: compounds 4, 2 and 1 (each within the scatter of the next, the first and the last beyond it).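

The series now has its first pair that differs in one place: in this assay, isopropylamino in place of (2-methoxyethyl)(methyl)amino on a sulfonyl sulfur gives a 1.8-fold lower number from compound 2 to compound 4 (0.24 log units; within the scatter). At this place, a group with 0 hydrogen-bond donors and 1 hydrogen-bond acceptor and a group with 1 hydrogen-bond donor and 0 hydrogen-bond acceptors therefore cannot be told apart by this read-out. No accompanying measurement bears on this result, so it stands as an observation on a single pair.

Open, on these data alone, is whether a different amine on the sulfonyl sulfur, such as morpholine or an unsubstituted amino group, would give a step beyond the scatter. Also open, as far as these compounds go, is whether replacing the carboxylic acid with a tetrazole would shift the unbound fraction in this assay.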